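The source may report more compounds than this note shows. Statements on the series, on what has been measured and on what is new or still open speak of the compounds shown alone.

Measured compounds:
compound 1 `Cn1c(-c2ccccc2)nc2c(NC3CCCCC3)ncnc21` — 2370 nM
compound 2 `CCCn1c(-c2ccccc2)nc2c(NC3CCC3)ncnc21` — 264 nM

In an assay on CHO cells for displacement of a labelled ligand from adenosine receptor A3 (Homo sapiens), read by scintillation counting, with a stated time of 3 h (on this read-out lower numbers stand for stronger inhibition and higher numbers for weaker inhibition), compound 2 gives 264 nM, the lowest of the two numbers. Among the measured compounds shown here, compound 1 gives 2370 nM in this assay, a higher number that lies beyond the scatter; compound 1 differs from compound 2 in two places at once, so no single step between the two is known. Compound 3 `Cn1c(-c2ccccc2)nc2c(NC3CCC3)ncnc21` takes up only one of those two differences: hydrogen in place of ethyl on a saturated chain carbon bound to an aromatic nitrogen. For the measured compounds named here, no measured pair shows this change on its own. The expectation is a moderate weakening, a step upward in this assay that should be beyond the scatter but smaller than the gap between compound 2 and compound 1, since that gap also carries the second difference. Compound 3 is therefore expected to give 800 nM, with a likely range of 250 nM to 2500 nM. The expected step is a 3.0-fold higher number from compound 2 to compound 3 (0.48 log units; beyond the scatter).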

Compound 3, inhibition constant: 280 nM
Compound 3: the middle estimate sits 2.9-fold (0.46 log units) above what was measured; the range from low to high includes it.
By their numbers in this assay, from the lowest: compounds 2 and 3 (each within the scatter of the next); then compound 1.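

In this assay, propyl to methyl at this place, on a saturated chain carbon bound to an aromatic nitrogen, gives a 1.1-fold higher number from compound 2 to compound 3 (0.03 log units; within the scatter), so the two chains are not told apart here when the nitrogen on the aromatic ring carries cyclobutyl. Among the compounds shown here, with methyl held constant, cyclobutyl in place of cyclohexyl on a nitrogen on an aromatic ring gives an 8.5-fold lower number from compound 1 to compound 3 (0.93 log units; beyond the scatter), the first single-place change to show a step beyond the scatter. No measurement at hand gives a reason for either step.

Still open, as far as these compounds go, is whether a longer chain such as butyl, or a chain ending in an amine or a carboxylic acid, would leave the value unchanged. Also open, from the compounds shown here alone, are how cyclopentyl would compare on that nitrogen and whether the cyclohexyl to cyclobutyl step holds with propyl as the chain.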